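Replacing the 4-nitrophenyl group of compound 3

A few compounds are considered here, and "the series" means these few. Any claim that something is new, unique, unknown or untested is made for them only; others in the source may bear on it.

In a functional assay on PC-3 cells (Homo sapiens) for cytotoxicity, read by MTT assay, with a stated time of 48 h (on this read-out higher numbers stand for weaker inhibition and lower numbers for stronger inhibition), compound 1 `COc1ccc(-c2cn(C(=O)Nc3cc(OC)c(OC)c(OC)c3)c(=O)n2-c2cc(OC)c(OC)c(OC)c2)cc1O` gives > 50000 nM, which is a limit of the assay and not a number.

Two compounds give actual numbers. Compound 2 `COc1cc(-n2c(-c3ccc(Br)cc3)cn(C(C)=O)c2=O)cc(OC)c1OC` gives 3100 nM, and compound 3 `COc1cc(-n2c(-c3ccc([N+](=O)[O-])cc3)cn(C(C)=O)c2=O)cc(OC)c1OC` gives 32900 nM. Compound 3 therefore holds the higher of the two numbers, and so the weaker inhibition, with compound 2 as its nearest neighbour.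

The next compound to be measured is compound 4 `COc1ccc(-c2cn(C(C)=O)c(=O)n2-c2cc(OC)c(OC)c(OC)c2)cc1N`, in which 3-amino-4-methoxyphenyl stands in place of 4-nitrophenyl on an aromatic carbon of the five-membered aromatic ring: 3-amino-4-methoxyphenyl in place of 4-nitrophenyl on an aromatic carbon.

Among the compounds with values here, one measured step bears on this change, as it alters the same aryl group at the same place. That step, with nitro in place of bromo, is an 11-fold higher number from compound 2 to compound 3 (1.03 log units; beyond the scatter), which is large and beyond the scatter. Within the data shown here, it is only a partial guide, since compound 4 loses the nitro group but also gains an amino and a methoxy group, and no measured step tests either of those.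

A step of similar size is expected in this assay, towards a lower number, on the evidence of an 11-fold higher number from compound 2 to compound 3 (1.03 log units; beyond the scatter). The estimated change is a 22-fold lower number from compound 3 to compound 4 (1.34 log units; beyond the scatter).

For compound 4 the expected value is 1500 nM, with an estimated range of 80 nM to 20000 nM.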

Compound 4, half-maximal inhibitory concentration: 21400 nM
The estimate for compound 4 lay 14-fold (1.15 log units) below the measured number, outside the stated range (above it).
By their numbers in this assay, from the lowest: compound 2; then compounds 4 and 3 (each within the scatter of the next). At a limit, above all of these: compound 1.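

In this assay, the exchange of 4-nitrophenyl for 3-amino-4-methoxyphenyl gives a 1.5-fold lower number from compound 3 to compound 4 (0.19 log units; within the scatter), so the two compounds sit level and removing the nitro group does not by itself restore the number of the bromo compound. Against 4-bromophenyl, the new aryl group gives a 6.9-fold higher number from compound 2 to compound 4 (0.84 log units; beyond the scatter), and together with an 11-fold higher number from compound 2 to compound 3 (1.03 log units; beyond the scatter) this sets compound 2 apart from both other acetyl compounds, the first sign that the outcome at this position does not simply follow the presence or absence of the nitro group. Nothing measured here gives a cause for the separation of 4-bromophenyl from the other two aryl groups.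

The amino and methoxy groups enter together in compound 4, so a 3-aminophenyl or a 4-methoxyphenyl group alone would be needed to tell their contributions apart at this place. From the compounds shown here alone, it also remains open whether a 4-chlorophenyl or 4-fluorophenyl group on the same aromatic carbon would stay near compound 2, or whether the lower number belongs to bromo alone within this short acetyl series.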